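From compound 2 to compound 3: one fluoro replaced

The source may hold more compounds than are shown below. What is called first, only, known or untested is meant among the compounds shown, and "the series" means these compounds.

Measured so far in a physicochemical assay for lipophilicity, read by HPLC, at pH 7.4; a higher number here means a more lipophilic compound, a lower number a more polar compound
Compound 1 `COc1ccc(-c2cc(-c3ccc(S(C)(=O)=O)cc3)cnc2N)cn1` gives 2.2
Compound 2 `CS(=O)(=O)c1ccc(-c2cnc(N)c(-c3ccc(C(F)(F)F)c(F)c3)c2)cc1` gives 3.1

Of the two measured compounds, compound 2 (3.1) stands higher. Compound 1 (2.2) lies lower, and the gap between them is beyond the usual scatter. Among the compounds with values here, the two do not form a one-place pair, so the series holds no measured step to serve as a direct guide.

The next compound is compound 3 `CS(=O)(=O)c1ccc(-c2cnc(N)c(-c3ccc(C(F)(F)F)cc3)c2)cc1`. It keeps the structure of compound 2 except for hydrogen in place of fluoro on an aromatic carbon, ortho to a trifluoromethyl group (hydrogen in place of fluoro on an aromatic carbon). The trifluoromethyl group itself stays.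

Within the data shown here, with only this small change, the value of compound 2 (3.1) is the natural starting point for the expectation. A slight fall in this assay is expected, small enough to stay within the scatter. The expected step is a number 0.20 log units lower from compound 2 to compound 3 (within the scatter) and remains an estimate until measured. The estimated value for compound 3 is 2.9 with an expected range from 2.6 to 3.2 as its limits.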

Compound 3, distribution coefficient: 3.4
Beside the measured number, compound 3's estimate is 0.50 log units below it; the whole stated range lies below it.
By their numbers in this assay, from the lowest: compound 1; then compounds 2 and 3 (each within the scatter of the next).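

In this assay, this series now has its first one-place step: hydrogen in place of fluoro on an aromatic carbon, ortho to a trifluoromethyl group and meta to a large group, gives a number 0.30 log units higher from compound 2 to compound 3 (within the scatter). At this position, the exchange therefore does not separate the two compounds on this read-out, so the fluoro can be treated as interchangeable with hydrogen for this measurement, at least with the trifluoromethyl group in place and the rest of the structure unchanged. Nothing available bears on why this exchange gives a step of this size.

The compounds shown leave open how far this aromatic carbon tolerates other substitution, for example whether a chloro, a primary amine or a carboxylic acid there would stay within the scatter of compound 3 at 3.4 or move clearly away from it. Also open, going by these compounds, is whether the same exchange of fluoro for hydrogen would give a similar step if a nitrile took the place of the trifluoromethyl group, as this single pair shows it in one setting only.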